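The compounds below may be only part of what the source reports. "The series", "measured", "known", "first", "only" and "open" are said of these compounds alone.

Compound 1 `CC1=NN(S(=O)(=O)c2ccc(C)cc2)C(c2cc(Br)ccc2O)C1`: 30700 nM
Compound 2 `CC1=NN(C(=O)CN2CCC(Cl)CC2)C(c2ccccc2O)C1`: 30300 nM
Compound 3 `Cc1ccc(C(=O)N2N=C(c3cc4ccccc4oc3=O)CC2c2ccccc2)cc1`: 31300 nM

All three compounds were tested in a functional assay on MGC-803 cells (Homo sapiens) for cytotoxicity, read by MTT assay, with a stated time of 48 h (on this read-out lower numbers stand for stronger inhibition and higher numbers for weaker inhibition), and their values lie within the scatter of one another, so compound 3 stands level with the other two. Compound 4 `O=C(CNC1CC1)N1N=C(c2cc3ccccc3oc2=O)CC1c1ccccc1` carries (cyclopropylamino)methyl in place of 4-methylphenyl on a carbonyl carbon. Within the data shown here, no measured pair differing in one place is available to size this change. Compound 2, whose different structure still gives 30300 nM, offers only a weak guide. In this assay, no step beyond the scatter is expected, with a slight lean towards a lower number. The expected change is a 1.4-fold lower number from compound 3 to compound 4 (0.15 log units; within the scatter). For compound 4 the estimated value is 22000 nM, within an expected range of 7000 nM to 55000 nM.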

Compound 4, half-maximal inhibitory concentration: "not active" (no number reported)
Compound 4: no number reported; the estimate stays without a comparison.
By their numbers in this assay, from the lowest: compounds 2, 1 and 3 (each within the scatter of the next).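

Among these compounds, compound 4 was reported as "not active" in this assay without a number, so no step from compound 3 to compound 4 can be read. No evidence shown bears on this result. On these data alone, how far (cyclopropylamino)methyl in place of 4-methylphenyl shifts the read-out stays open.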